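Carbonyl substituent swap from compound 1 to compound 4

The source may hold more compounds than are shown below. What is called first, only, known or untested is meant among the compounds shown, and "the series" means these compounds.

Measured in a functional assay on HepG2 cells (Homo sapiens) for antiproliferative activity, read by MTT assay, with a stated time of 48 h; a higher number here means a weaker inhibitor, a lower number a stronger inhibitor:
- compound 1 `CCn1c(C(=O)NCC#N)ccc1C(CC)(CC)c1ccc(OCCC(O)(CC)CC)c(C)c1`: > 50000 nM (a limit)
- compound 2 `CCn1c(C(=O)N(CCC#N)CCC#N)ccc1C(CC)(CC)c1ccc(OCCC(O)(CC)CC)c(C)c1`: 46300 nM
- compound 3 `C=CCN(C)C(=O)c1ccc(C(CC)(CC)c2ccc(OCCC(O)(CC)CC)c(C)c2)n1CC`: > 50000 nM (a limit)

Compound 1 stands at > 50000 nM, which is a limit and not a number. The set as a whole shows (the limit of > 50000 nM in this assay, at which 2 of the 3 values shown sit).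

Compound 4 `C#CCCOC(=O)c1ccc(C(CC)(CC)c2ccc(OCCC(O)(CC)CC)c(C)c2)n1CC` carries (but-3-yn-1-yl)oxy in place of (cyanomethyl)amino on a carbonyl carbon.

Three measured steps change the group at the same place: an at least 1.0-fold lower number from compound 1 to compound 2 (0.03 log units; that floor lies within the scatter), then a step that the two limits leave unreadable from compound 1 to compound 3, and finally an at least 1.0-fold higher number from compound 2 to compound 3 (0.03 log units; that floor lies within the scatter). None of them reads as a step beyond the scatter. Going by the values given here, compound 2, at 46300 nM, gives the only actual number. With an at least 1.0-fold lower number from compound 1 to compound 2 (0.03 log units; that floor lies within the scatter) as the nearest readable guide, no step beyond the scatter is expected in this assay, and no direction can be assigned. The estimate amounts to a number no higher from compound 1 to compound 4 (the limit leaves the size open). Compound 4 is expected at 50000 nM, with an estimated range of 25000 nM to 100000 nM, and a report of a limit alone would be no surprise.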

Compound 4, half-maximal inhibitory concentration: > 50000 nM
Compound 4: only a limit was reported; the forecaster's own chance of this, stated with the estimate: 65%; the middle value sits exactly at the limit.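

In this assay, the carbonyl carbon now carries an oxygen-linked group, (but-3-yn-1-yl)oxy, where compounds 1, 2 and 3 all carry a nitrogen-linked group, and the result is again a limit: the limit of > 50000 nM in this assay, at which 3 of the 4 values shown sit.

Going by these compounds alone, the one readable step is an at least 1.0-fold higher number from compound 2 to compound 4 (0.03 log units; that floor lies within the scatter); the steps joining compound 4 to compound 1 and compound 3 cannot be read, as both ends are limits. Neither replacing the amide nitrogen with oxygen nor losing the hydrogen-bond donor of compound 1 gives a reading that can be separated from the rest of the set.

Still open, on these data alone, is whether any group on this carbonyl carbon can lower the number beyond the scatter, and how a carboxylic acid or a morpholine amide would read here. The compounds shown also leave open whether changes elsewhere on the shared core would shift the level.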